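A few compounds are considered here, and "the series" means these few. Any claim that something is new, unique, unknown or untested is made for them only; others in the source may bear on it.

Measured compounds:
compound 1 `COc1ccc(-c2cn3ccnc3c(-c3ccc4ncn(C5CCCCC5)c4c3)n2)cc1` — 80.9%
compound 2 `CC(=O)c1ccc(-c2cn3ccnc3c(-c3ccc4ncn(C5CCCCC5)c4c3)n2)cc1` — 3.02%
compound 3 `Clc1ccc(-c2cn3ccnc3c(-c3ccc4ncn(C5CCCCC5)c4c3)n2)cc1` — 11.3%

In a functional assay on U-251 cells (Homo sapiens) for inhibition, read by sulforhodamine B assay, with a stated time of 48 h, tested at 10 uM (a lower number here means less inhibition, a higher number more inhibition at the concentration tested (going by the name of the read-out)), compound 3 stands second of the three numbers shown. Its neighbour is compound 2 a number 8.3 percentage points higher from compound 2 to compound 3 (within the scatter), a gap within the scatter; its distant partner is compound 1, reached by a number 69.6 percentage points lower from compound 1 to compound 3 (beyond the scatter), a large step beyond the scatter.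

Compound 4 `COc1ccccc1-c1cn2ccnc2c(-c2ccc3ncn(C4CCCCC4)c3c2)n1` has not yet been measured in this assay. It differs from compound 3 in one place: 2-methoxyphenyl in place of 4-chlorophenyl on an aromatic carbon.

Within the data shown here, only one measured step bears on this change. It is a number 69.6 percentage points lower from compound 1 to compound 3 (beyond the scatter), which runs in the opposite direction and shows that moving from a methoxy to a chloro on the aromatic carbon cost a large amount of inhibition. Reversing that exchange should be expected to return a large part of it. Among the measured compounds shown here, the methoxy of compound 1, however, is not arranged on its phenyl ring as the 2-methoxyphenyl of compound 4 is, and no measured compound tests that arrangement, so the step is expected to be smaller and less certain than a plain reversal. Compound 4 is therefore expected to gain, with a number 33.7 percentage points higher from compound 3 to compound 4 (beyond the scatter) as the estimated step, landing at an estimated 45% with a range of 10% to 80%.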

Compound 4, a percentage reported as inhibition, at one concentration (the size of the read-out at that concentration, not a potency): 21%
The estimate for compound 4 lay 24 percentage points above the measured number; measured number inside the range.
By their numbers in this assay, from the lowest: compounds 2, 3 and 4 (each within the scatter of the next, the first and the last beyond it); then compound 1.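

In this assay, the methoxy group alone does not secure the inhibition seen with compound 1: 2-methoxyphenyl in place of 4-methoxyphenyl gives a large drop (a number 59.9 percentage points lower from compound 1 to compound 4 (beyond the scatter)), so the same group on the same phenyl ring does not give the same result once its place on that ring changes. Compound 4 is not separated from compound 3 (a number 9.7 percentage points higher from compound 3 to compound 4 (within the scatter)), and it differs only modestly from compound 2 (a number 18 percentage points higher from compound 2 to compound 4 (beyond the scatter)), which leaves compound 1 alone at the high end of these four compounds. Nothing measured here explains why moving the methoxy group has so large an effect.

Going by these compounds, whether an amine, a hydroxyl group or a longer ether chain on the phenyl ring, at the place the methoxy group holds in compound 1, would keep that inhibition stays open. These readings also come from a single concentration, so they leave open how the potencies of these compounds compare.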